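The source may hold more compounds than are shown below. What is called first, only, known or untested is meant among the compounds shown, and "the series" means these compounds.

Compound 1 `CC1(C)[C@@H](Cn2nnc3c(N)nc(N)nc32)CC[C@@]1(C)CO` and compound 2 `CC(=O)OCCOCn1cnc2c(Cl)nc(Cl)nc21` are the two members measured in an ADME assay on L1210/0 cells (Mus musculus) for cytotoxicity, with a stated time of 48 h; a higher number here means a weaker inhibitor, a lower number a stronger inhibitor. For compound 1 that assay returns only a limit, > 200000 nM, not a number. Going by the values given here, compound 2 gives 39300 nM, the sole number in hand. The other value shown for the series is a limit (the limit of > 200000 nM in this assay, at which 1 of the 2 values shown sits). Compound 3 `CC(=O)OCCOCn1cnc2c(Cl)ncnc21` is not yet measured. It differs from compound 2 by hydrogen in place of chloro on an aromatic carbon. Among the compounds with values here, no measured pair isolates this change, so nothing sizes it. The step is expected to be small, a 1.3-fold higher number from compound 2 to compound 3 (0.10 log units; within the scatter) in this assay, within the scatter. Compound 3 is estimated at 50000 nM, with a range from 15000 nM to 200000 nM.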

Compound 3, half-maximal inhibitory concentration: 163000 nM
Compound 3: middle estimate off by 3.3-fold (0.51 log units), on the low side, and the stated range covers the measured number.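

In this assay the change from chloro to hydrogen on the aromatic carbon between two ring nitrogen atoms gives a 4.1-fold higher number from compound 2 to compound 3 (0.62 log units; beyond the scatter), so this position is not neutral. With everything else held constant, this chloro accounts for part of the activity of compound 2. For compound 1 the read-out remains a limit, which caps what can be sized in the series: the limit of > 200000 nM in this assay, at which 1 of the 3 values shown sits.

The compounds shown leave open whether a group other than chloro, such as an amine or a methoxy group, would hold the activity at this carbon. As far as these compounds go, what the remaining chloro contributes also stays open.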